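This account rests on a few compounds, and the source may have more. Where it says the series, first, only, none or still open, it means among the compounds named here.

In a functional assay for inhibition, with Homo sapiens as the target (a lower number here means a stronger inhibitor, a higher number a weaker inhibitor), compound 1 `O=C(O)CCNC(=O)c1ccc2c(c1)C(=O)N(CCC1CCNCC1)C2` gives 27 nM, and compound 2 `CCCCCS(=O)(=O)N[C@@H](CNC(=O)c1ccc2c(c1)C(=O)N(CCC1CCNCC1)C2)C(=O)O` gives 9 nM, the lower of the two numbers and so the stronger inhibitor so far. Compound 3 `CCCCCC(=O)N[C@@H](CNC(=O)c1ccc2c(c1)C(=O)N(CCC1CCNCC1)C2)C(=O)O` differs from compound 2 in one place: pentylcarbonyl in place of pentylsulfonyl on an amine nitrogen. In words, pentylcarbonyl stands in place of pentylsulfonyl on an amine nitrogen, so the chain stays and the group linking it changes. Among the measured compounds shown here, no measured step tests this swap directly. For the measured compounds named here, the only guide is a 3.0-fold lower number from compound 1 to compound 2 (0.48 log units; beyond the scatter), which came with adding the whole (pentylsulfonyl)amino group. Since that whole addition brought only a modest change, swapping part of it should move the number less, and probably part of the way back upward. The expected change is a 1.7-fold higher number from compound 2 to compound 3 (0.22 log units; within the scatter), a small rise that may not clear the scatter. For compound 3 the estimated value is 15 nM, with an expected range of 5 nM to 45 nM.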

Compound 3, half-maximal inhibitory concentration: 13 nM
For compound 3 the middle estimate is 1.2-fold (0.06 log units) above the measured one; low and high end bracket the measured number.
By their numbers in this assay, from the lowest: compounds 2 and 3 (each within the scatter of the next); then compound 1.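

Swapping pentylsulfonyl for pentylcarbonyl on the amine nitrogen gives a 1.4-fold higher number from compound 2 to compound 3 (0.16 log units; within the scatter) and so leaves compounds 2 and 3 indistinguishable, which shows that this position accepts either link. The carbonyl version also keeps a gain over the hydrogen of compound 1, with a 2.1-fold lower number from compound 1 to compound 3 (0.32 log units; beyond the scatter), so the sulfonyl is not needed for that gain. No measurement is available that would explain these results.

Still open, as far as these compounds go, is how much of the gain belongs to the pentyl chain rather than to the link that carries it, and a shorter chain such as propyl on the same carbonyl would speak to that. Also open, from the compounds shown here alone, is whether any link is needed, which a plain amine at this position would show.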